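From phenyl to 2-carboxyethyl on compound 3

The source may report more compounds than this note shows. Statements on the series, on what has been measured and on what is new or still open speak of the compounds shown alone.

- Compound 1 `O=C(O)c1cc2ccc(-c3ccc(Cl)cc3)cc2n1O` gives > 100000 nM
- Compound 2 `O=C(O)c1cc2ccc(-c3ccc(F)cc3)cc2n1O` gives > 100000 nM
- Compound 3 `O=C(O)c1cc2ccc(-c3ccc(-c4ccccc4)cc3)cc2n1O` gives > 100000 nM

In an ADME assay on HS27 cells (Homo sapiens) for antiproliferative activity, read by sulforhodamine B assay, with a stated time of 48 h (on this read-out higher numbers stand for weaker inhibition and lower numbers for stronger inhibition), compound 3 gives > 100000 nM and this is a limit, not a number. The entries for compound 1 and compound 2 are limits too.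

Compound 4 `O=C(O)CCc1ccc(-c2ccc3cc(C(=O)O)n(O)c3c2)cc1` carries 2-carboxyethyl in place of phenyl on an aromatic carbon, para to a large group (2-carboxyethyl in place of phenyl on an aromatic carbon). Two measured steps also involve phenyl: (a step that the two limits leave unreadable from compound 1 to compound 3) and (a step that the two limits leave unreadable from compound 2 to compound 3). Neither has a readable size, so neither gives a direction.

Compound 3 and its two relatives share the limit of > 100000 nM in this assay, at which 3 of the 3 values shown sit, and so in this assay compound 4 is expected to show no step beyond the scatter. The estimate for compound 4 is 100000 nM within a range from 50000 nM to 200000 nM and it may well prove to be only a limit. That estimate means an expected step (a number no higher from compound 3 to compound 4 (the limit leaves the size open)).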

Compound 4, half-maximal inhibitory concentration: > 100000 nM
Compound 4 gave a limit, no number (the forecaster's own chance of this, stated with the estimate: 85%); the middle value sits exactly at the limit.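

In this assay compound 4 gives > 100000 nM, which is a limit and not a number. Its steps from compound 1, compound 2 and compound 3 therefore cannot be read. The compounds shown leave open how these four truly compare in this assay.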